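A few compounds are considered here, and "the series" means these few. Any claim that something is new, unique, unknown or untested is made for them only; others in the source may bear on it.

Working notes on the series. In a functional assay on DU-145 cells (Homo sapiens) for cytotoxicity, read by XTT assay, with a stated time of 24 h (on this read-out lower numbers stand for stronger inhibition and higher numbers for weaker inhibition), compound 1 (`COc1c(C)cc(Cl)c2c1C(=O)C=CC2=O`) gives 36500 nM, compound 2 (`COc1cc(C)c(Cl)c2c1C(=O)C=CC2=O`) gives 26600 nM, and compound 3 (`CCOc1cc(C)cc2c1C(=O)C=CC2=O`) gives 15000 nM. Compound 1 lies within the scatter of compound 2, while compound 3 has a lower number than compound 1, beyond the scatter.

Compound 4 (`CCOc1c(C)cc(Cl)c2c1C(=O)C=CC2=O`) keeps the core of compound 1 with a single change, methyl in place of hydrogen on a saturated chain carbon bound to an oxygen on an aromatic ring, which turns methoxy into ethoxy. Ethoxy also occurs in compound 3, but that compound differs from compound 1 in more than one place, so no measured pair isolates this change. The only ethoxy reference is therefore indirect, with compound 3 at 15000 nM, and it supports at most a slight expected move towards a lower number. The estimated 1.3-fold lower number from compound 1 to compound 4 (0.12 log units; within the scatter) is expected to stay within the scatter. For compound 4 the estimate in this assay is 28000 nM, with an expected range of 13000 nM to 55000 nM.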

Compound 4, half-maximal inhibitory concentration: 26200 nM
Compound 4: middle estimate off by 1.1-fold (0.03 log units), on the high side; measured number inside the range.
By their numbers in this assay, from the lowest: compounds 3, 4, 2 and 1 (each within the scatter of the next, the first and the last beyond it).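

In this assay, the change from methoxy to ethoxy gives a 1.4-fold lower number from compound 1 to compound 4 (0.14 log units; within the scatter), so at this position the added methyl leaves the number within the scatter. Within the data shown here, this is the first pair that isolates the change, and it replaces the indirect ethoxy reference with a direct reading on the core of compound 1. No measurement bears on what lies behind this small step.

From the compounds shown here alone, whether the position would tolerate a longer chain such as propoxy or butoxy, or a chain ending in an amine or a carboxylic acid, stays open. A single pair also leaves open whether the same change would read alike on compound 2, which carries methoxy too.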